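Methyl for fluoro on the pyridine ring of a thienopyrimidinone

A few compounds are considered here, and "the series" means these few. Any claim that something is new, unique, unknown or untested is made for them only; others in the source may bear on it.

Measured so far:
compound 1 `COc1cccc(Cn2cnc3sc(-c4ccncc4)cc3c2=O)c1` gives 6 nM
compound 2 `COc1cccc(Cn2cnc3sc(-c4ccnc(F)c4)cc3c2=O)c1` gives 83 nM

Both compounds were tested in an assay on isolated protein for inhibition of Rho-associated protein kinase 2 (Homo sapiens), read by radiometric assay and 33P incorporation, with a stated time of 40 min, in the presence of a further agent that is not named here; on this read-out higher numbers stand for weaker inhibition and lower numbers for stronger inhibition. Among the two numbers shown, compound 2 has the highest; its nearest neighbour is compound 1, and the step of a 14-fold higher number from compound 1 to compound 2 (1.14 log units; beyond the scatter) is the only measured one, and it is large. Compound 3 `COc1cccc(Cn2cnc3sc(-c4ccnc(C)c4)cc3c2=O)c1` is not yet measured. It differs from compound 2 by methyl in place of fluoro on an aromatic carbon, on an aromatic carbon of a six-membered aromatic ring with 1 nitrogen, next to the ring nitrogen. Among the compounds with values here, the only step that bears on this position is the one from compound 1 to compound 2, which shows the assay responds strongly to what sits there. Whether methyl behaves like fluoro or like hydrogen is not shown. Compound 3 is therefore expected to give a lower number than compound 2, a step of about a 5.5-fold lower number from compound 2 to compound 3 (0.74 log units; beyond the scatter), with the estimate 15 nM and a range from 4 nM to 60 nM.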

Compound 3, half-maximal inhibitory concentration: 42 nM
Beside the measured number, compound 3's estimate is 2.8-fold (0.45 log units) below it, within the range that was stated.
By their numbers in this assay, from the lowest: compound 1; then compounds 3 and 2 (each within the scatter of the next).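

In this assay, methyl and fluoro cannot be told apart at this position next to the ring nitrogen, as the exchange gives a 2.0-fold lower number from compound 2 to compound 3 (0.30 log units; within the scatter) and so stays within the scatter. Methyl in place of hydrogen gives a 7.0-fold higher number from compound 1 to compound 3 (0.85 log units; beyond the scatter) and thus lies beyond the scatter, which shows that the drop from the hydrogen of compound 1 is not confined to fluoro but also appears with a group of a different element. Nothing here explains why the hydrogen stands apart from both groups.

Going by these compounds, whether any group at this position can match hydrogen remains open. An amine, a methoxy group or a longer chain such as ethyl would show whether the loss holds beyond compound 2 and compound 3.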